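Cyanobenzyl in place of methoxyphenyl on the ring nitrogen

The source may hold more compounds than are shown below. What is called first, only, known or untested is meant among the compounds shown, and "the series" means these compounds.

Measured so far, in a functional assay on HepG2 cells (Homo sapiens) for inhibition, read by MTT assay, with a stated time of 72 h; a higher number here means a weaker inhibitor, a lower number a stronger inhibitor:
compound 1 `Cc1ccc(-n2cc(CNC(=O)c3cccc4c3cnn4C(C)C)nn2)cc1C` gives > 40000 nM
compound 2 `Cc1ccccc1-n1cc(CNC(=O)c2cccc3c2cnn3C(C)C)nn1` gives > 40000 nM
compound 3 `COc1ccc(-n2cc(CNC(=O)c3cccc4c3cnn4C(C)C)nn2)cc1` gives > 40000 nM

None of these three values is a number; each is a limit of the assay, (the limit of > 40000 nM in this assay, at which 3 of the 3 values shown sit). Because every value sits at that limit, the steps between the measured compounds cannot be read: a step that the two limits leave unreadable from compound 1 to compound 2, a step that the two limits leave unreadable from compound 1 to compound 3 and a step that the two limits leave unreadable from compound 2 to compound 3. Compound 3 therefore stands where compound 1 and compound 2 stand, at the limit, with no readable difference among the three.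

Compound 4 `CC(C)n1ncc2c(C(=O)NCc3cn(Cc4ccc(C#N)cc4)nn3)cccc21` differs from compound 3 in one place: 4-cyanobenzyl in place of 4-methoxyphenyl on an aromatic nitrogen. For the measured compounds named here, no measured step bears on this change with a readable size, since every step among compound 1, compound 2 and compound 3 is hidden by the limit. Going by the values given here, the only guide is that all three measured compounds fail to show inhibition within the range of this assay. The step from compound 3 to compound 4 is expected to be none readable beyond the scatter, a number no higher from compound 3 to compound 4 (the limit leaves the size open). Compound 4 is accordingly estimated at 40000 nM, with a range from 15000 nM to 100000 nM, and most likely reported again only as a limit.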

Compound 4, half-maximal inhibitory concentration: > 40000 nM
Compound 4 gave a limit, no number (the forecaster's own chance of this, stated with the estimate: 75%); the middle value lies on the limit itself.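

In this assay compound 4 gives > 40000 nM as a limit and not a number. The steps to compound 4 from compound 1, compound 2 and compound 3 therefore cannot be read: the limit of > 40000 nM in this assay, at which 4 of the 4 values shown sit. The compounds shown leave open which group on the aromatic nitrogen, if any, would give a readable value in this assay.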